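Indolyl in place of cyanobenzyl on the ring nitrogen

A few compounds are considered here, and "the series" means these few. Any claim that something is new, unique, unknown or untested is made for them only; others in the source may bear on it.

Three compounds share one core and differ only in the group carried on an aromatic nitrogen. In a functional assay on SGC-7901 cells (Homo sapiens) for inhibition, read by MTT assay, with a stated time of 72 h (a higher number here means a weaker inhibitor of growth, a lower number a stronger inhibitor of growth), compound 1 `O[C@H](COCCOC[C@@H](O)Cc1cn(-c2cncnc2)nn1)Cc1ccc(-c2ccccc2)cc1` reaches only a limit of the assay, > 100000 nM (the limit of > 100000 nM in this assay, at which 1 of the 3 values shown sits). Compound 2 `O[C@H](COCCOC[C@@H](O)Cc1cn(-c2cccnc2)nn1)Cc1ccc(-c2ccccc2)cc1` gives 29800 nM in this assay, and compound 3 `N#Cc1ccc(Cn2cc(C[C@H](O)COCCOC[C@@H](O)Cc3ccc(-c4ccccc4)cc3)nn2)cc1` gives 7700 nM. Among the numbers shown compound 3 stands lowest: the step of a 3.9-fold lower number from compound 2 to compound 3 (0.59 log units; beyond the scatter) is modest, the step of an at least 12-fold lower number from compound 1 to compound 3 (1.11 log units; beyond the scatter) is large, and an at least 3.3-fold lower number from compound 1 to compound 2 (0.52 log units; beyond the scatter) is at least modest. Compound 4 `O[C@H](COCCOC[C@@H](O)Cc1cn(-c2ccc3[nH]ccc3c2)nn1)Cc1ccc(-c2ccccc2)cc1` carries the change (1H-indol-5-yl in place of 4-cyanobenzyl on an aromatic nitrogen). The measured steps bear on it only in part: they show that a 4-cyanobenzyl group gives lower numbers than either pyrimidin-5-yl or pyridin-3-yl attached directly to the nitrogen, and 1H-indol-5-yl is again a directly attached aromatic group, though unlike either of those. A step back toward a higher number in this assay is therefore expected, of a size near that seen from compound 2 to compound 3, and the estimate is a 2.3-fold higher number from compound 3 to compound 4 (0.37 log units; beyond the scatter). Compound 4 is accordingly expected to give about 18000 nM in this assay, within a range from 4500 nM to 70000 nM.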

Compound 4, concentration for 50% growth inhibition: 45600 nM
Compound 4: the middle estimate sits 2.5-fold (0.40 log units) below what was measured; the measured number falls inside the stated range.
By their numbers in this assay, from the lowest: compound 3; then compounds 2 and 4 (each within the scatter of the next). At a limit, above all of these: compound 1.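

At this aromatic nitrogen in this assay, 1H-indol-5-yl in place of 4-cyanobenzyl, a group with the same count of heavy atoms, gives a 5.9-fold higher number from compound 3 to compound 4 (0.77 log units; beyond the scatter); compound 3 thus keeps the lowest number, and all three groups attached directly through an aromatic ring, in compounds 1, 2 and 4, give higher readings than it does. The larger two-ring indolyl group does not separate itself from the single-ring pyridin-3-yl group, as a 1.5-fold higher number from compound 2 to compound 4 (0.18 log units; within the scatter) shows. Compound 4 still stands apart from compound 1, with an at least 2.1-fold lower number from compound 1 to compound 4 (0.34 log units; beyond the scatter), though compound 1 gives only a limit of the assay and not a number: the limit of > 100000 nM in this assay, at which 1 of the 4 values shown sits.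

The compounds shown leave open whether the lower number of compound 3 goes with the benzyl link or with the nitrile, which an unsubstituted benzyl group or a 4-cyanophenyl group attached directly to the ring nitrogen would separate. They also leave open how an amine or a carboxylic acid in place of the nitrile on the benzyl ring would read in this assay.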